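Ether substituent variation on the shared core

The source may report more compounds than this note shows. Statements on the series, on what has been measured and on what is new or still open speak of the compounds shown alone.

Measured in a functional assay on HEK293 cells for agonist activity at G-protein coupled receptor 39 (Homo sapiens), read by scintillation proximity assay and inositol phosphate accumulation, with a stated time of 75 min, in the presence of a further agent that is not named here; a higher number here means that more compound is needed for the effect, a lower number that less compound is needed:
Compound 1 `Cc1nn(-c2ncnc3nc[nH]c23)c2c1C(OC1CCCC1)CC(=O)N2` gives 2 nM.
Compound 2 `Cc1nn(-c2ncnc3nc[nH]c23)c2c1C(C(=O)Nc1ccccc1)CC(=O)N2` gives 10 nM.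
Compound 3 `Cc1cc(C)n(CCOC2CC(=O)Nc3c2c(C)nn3-c2ncnc3nc[nH]c23)n1` gives 16 nM.

Compound 3 carries the highest number of the three. Its distance from compound 1 lies beyond the scatter, an 8.0-fold higher number from compound 1 to compound 3 (0.90 log units; beyond the scatter), while its distance from compound 2 does not, a 1.6-fold higher number from compound 2 to compound 3 (0.20 log units; within the scatter). Compound 2 itself stands away from compound 1, a 5.0-fold higher number from compound 1 to compound 2 (0.70 log units; beyond the scatter).

Compound 4 `Cc1nn(-c2ncnc3nc[nH]c23)c2c1C(OCc1ccccc1C#N)CC(=O)N2` has not been measured. It differs from compound 3 in one place: 2-cyanophenyl in place of (3,5-dimethyl-1H-pyrazol-1-yl)methyl on a saturated chain carbon bound to an oxygen on a saturated carbon. Both measured steps away from compound 1 bear on this: a six-membered carbon-only aromatic ring at this region of the molecule (compound 2) and a five-membered ring with two hetero atoms (compound 3) end up within the scatter of each other. Swapping one aromatic ring for the other on the ether chain is therefore expected to give no step beyond the scatter in this assay, with at most a slight drift toward the value of compound 2. The estimate for compound 4 is 10 nM, range 3 nM to 35 nM. The expected step is a 1.6-fold lower number from compound 3 to compound 4 (0.20 log units; within the scatter).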

Compound 4, half-maximal effective concentration: 8 nM
Compound 4: the middle estimate sits 1.3-fold (0.10 log units) above what was measured, within the range that was stated.
By their numbers in this assay, from the lowest: compound 1; then compounds 4, 2 and 3 (each within the scatter of the next).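

In this assay, 2-cyanobenzyl and 2-(3,5-dimethyl-1H-pyrazol-1-yl)ethyl on the ether oxygen cannot be told apart (a 2.0-fold lower number from compound 3 to compound 4 (0.30 log units; within the scatter)), so a six-membered carbon-only aromatic ring bearing a nitrile and a five-membered aromatic ring with 2 hetero atoms give values within the scatter at this place. The ether with 2-cyanobenzyl also stays within the scatter of the phenylcarbamoyl group on the saturated ring carbon (a 1.3-fold lower number from compound 2 to compound 4 (0.10 log units; within the scatter)), while cyclopentyl on the oxygen remains separated from 2-cyanobenzyl (a 4.0-fold higher number from compound 1 to compound 4 (0.60 log units; beyond the scatter)), leaving compound 1 apart from all three compounds with aromatic-ring substituents. Nothing available here explains these differences.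

Open, going by these compounds, is whether unsubstituted benzyl on the oxygen would sit with compound 4, which would test the contribution of the nitrile. Also open, on these data alone, is how a primary amine, a carboxylic acid or a longer alkyl chain on the oxygen would compare with cyclopentyl.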